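Pyridine substituent swap on a shared acid core

The compounds below may be only part of what the source reports. "The series", "measured", "known", "first", "only" and "open" are said of these compounds alone.

Compound 1 `O=C(O)Cc1sc(C(c2ccccc2)c2ccccc2)nc1-c1ccccc1` gives 370 nM in an in vitro functional assay on HEK285-7 cells for antagonist activity at prostaglandin D2 receptor 2 (Homo sapiens), read by BRET and beta-arrestin recruitment; a lower number here means a stronger inhibitor, a higher number a weaker inhibitor. Compound 2 `Cc1nc(-c2ccc(Cl)cc2)c(CC(=O)O)s1` gives 41000 nM. Compound 3 `COc1cc(-c2nc(C(c3ccc(F)cc3)c3ccc(F)cc3)sc2CC(=O)O)ccn1` gives 380 nM.

Among these three values compound 3 holds the second highest number. Its nearest neighbour is compound 1, whose number lies so close that the two fall within the usual scatter of the assay, so no order between them can be claimed. The furthest is compound 2, whose number is far higher, well beyond the scatter, so compound 2 is clearly the weaker inhibitor of the pair.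

Compound 4 `Nc1cc(-c2nc(C(c3ccc(F)cc3)c3ccc(F)cc3)sc2CC(=O)O)cc(F)n1` has not yet been measured. It differs from compound 3 in one place:

2-amino-6-fluoropyridin-4-yl in place of 2-methoxypyridin-4-yl on an aromatic carbon

Among the measured compounds shown here, no measured pair shows this exact change, so there is no step to lean on. The core, the carboxymethyl group and the large group stay the same, and the entering group matches the leaving group in ring size and in the number of heavy atoms. The expectation is therefore a step of a 1.1-fold higher number from compound 3 to compound 4 (0.02 log units; within the scatter) of modest size, most likely none beyond the scatter. Compound 4 is expected to give about 400 nM, with a likely range from 150 nM to 1100 nM.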

Compound 4, half-maximal inhibitory concentration: 1400 nM
Estimate against measurement, compound 4: 3.5-fold (0.54 log units) below; the whole stated range lies below it.
By their numbers in this assay, from the lowest: compounds 1 and 3 (each within the scatter of the next); then compound 4; then compound 2.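

In this assay, putting 2-amino-6-fluoropyridin-4-yl in place of 2-methoxypyridin-4-yl gives a 3.7-fold higher number from compound 3 to compound 4 (0.57 log units; beyond the scatter), so the inhibitor is weaker and this aromatic carbon does not accept every pyridine equally. Both groups have one six-membered aromatic ring with 1 hetero atom and 8 heavy atoms, which shows that matching ring and size alone does not keep the potency of compound 3. Nothing shown here gives a reason for the loss.

From the compounds shown here alone, the methoxy group leaves while the amino group and the fluorine enter together, so it stays open which of these changes carries the step. A 2-aminopyridin-4-yl or a 2-fluoropyridin-4-yl group, each holding only one of the two new substituents, would be needed to tell them apart.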